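The source may hold more compounds than are shown below. What is called first, only, known or untested is meant among the compounds shown, and "the series" means these compounds.

Measured in an ADME assay on J774.A1 cells (Mus musculus) for cytotoxicity, read by MTT assay, with a stated time of 72 h; a lower number here means that less compound is tolerated, a higher number that more compound is tolerated:
compound 1, `CC1(c2ccc(-c3cccc(/C(N)=N\O)c3)cc2)CC(S(=O)(=O)c2ccc(F)cc2)=C(c2ccc(/C(N)=N\O)cc2)O1`: 11000 nM
compound 2, `CC1(c2ccc(Br)cc2)CC(S(=O)(=O)c2ccc(F)cc2)=C(c2ccc(/C(N)=N\O)cc2)O1`: 10500 nM
compound 3, `CC1(c2ccc(-c3cccc([N+](=O)[O-])c3)cc2)CC(S(=O)(=O)c2ccc(F)cc2)=C(c2ccc(/C(N)=N\O)cc2)O1`: 11100 nM

The three compounds share one core and differ only in a single group on an aromatic carbon. Compound 3 stands among three numbers that cannot be told apart: the step of a 1.0-fold higher number from compound 1 to compound 3 (0.00 log units; within the scatter) and the step of a 1.1-fold higher number from compound 2 to compound 3 (0.02 log units; within the scatter) both stay within the scatter, and so does the step of a 1.0-fold lower number from compound 1 to compound 2 (0.02 log units; within the scatter). Exchanging a whole ring-bearing group for a bromine atom, or one small group for another on that ring, left this assay without any resolvable change.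

Compound 4, `CC1(c2ccc(-c3ccc(/C(N)=N\O)cc3)cc2)CC(S(=O)(=O)c2ccc(F)cc2)=C(c2ccc(/C(N)=N\O)cc2)O1`, has not yet been measured. Its change from compound 3 is a group of 10 heavy atoms (7 carbon, 2 nitrogen, 1 oxygen; one six-membered aromatic ring of carbon only) in place of a group of 9 heavy atoms (6 carbon, 1 nitrogen, 2 oxygen; one six-membered aromatic ring of carbon only), on an aromatic carbon. The step that bears most directly on it is a 1.0-fold higher number from compound 1 to compound 3 (0.00 log units; within the scatter), run in the other direction, since compound 1 already carries the same kind of group in a different position on that ring, and the two ring-free steps show the same flat picture. No step beyond the scatter is therefore expected in this assay. Compound 4 is expected to give 11000 nM, estimated to lie between 5500 nM and 22000 nM. This estimate means an expected step of a 1.0-fold lower number from compound 3 to compound 4 (0.00 log units; within the scatter).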

Compound 4, half-maximal cytotoxic concentration: 3940 nM
Estimate against measurement, compound 4: 2.8-fold (0.45 log units) above; measured number outside the range, below it.
By their numbers in this assay, from the lowest: compound 4; then compounds 2, 1 and 3 (each within the scatter of the next).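

In this assay the ring position turns out to matter: moving the same group to the place para to a large group gives a 2.8-fold lower number from compound 1 to compound 4 (0.45 log units; beyond the scatter) and so separates two compounds that differ only in where that group sits, something the earlier exchanges, all within the scatter, never showed. Compound 4 also stands apart from the compounds carrying the other two groups, with a 2.7-fold lower number from compound 2 to compound 4 (0.43 log units; beyond the scatter) against the bromine compound and a 2.8-fold lower number from compound 3 to compound 4 (0.45 log units; beyond the scatter) against the 3-nitrophenyl compound, so less compound is tolerated with this group at this place than with any of the three earlier arrangements. Nothing available here explains why this placement shifts the number.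

The compounds shown cannot tell whether the shift needs this particular group or would follow any group at this place, and a ring bearing an amine or a carboxylic acid at the same spot would help to separate those two readings. As far as these compounds go, whether the same step appears in cells other than this single mouse line also remains open.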